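A few compounds are considered here, and "the series" means these few. Any claim that something is new, unique, unknown or untested is made for them only; others in the source may bear on it.

Compound 1 `CCn1c(C(=O)NCC#N)ccc1C(CC)(CC)c1ccc(OCCC(O)(CC)CC)c(C)c1` stands only at a limit in an ADME assay on L02 cells (Homo sapiens) for antiproliferative activity, read by MTT assay, with a stated time of 48 h; on this read-out higher numbers stand for weaker inhibition and lower numbers for stronger inhibition: in this assay compound 1 gives > 50000 nM, a limit rather than a number. Compound 2 `CCOc1ccc(NC(=O)c2ccc(C(CC)(CC)c3ccc(OCCC(O)(CC)CC)c(C)c3)n2CC)cc1` also gives > 50000 nM, again a limit. Compound 3 `CCOC(=O)C(CC(=O)OC)NC(=O)c1ccc(C(CC)(CC)c2ccc(OCCC(O)(CC)CC)c(C)c2)n1CC` gives 4280 nM. The step that the two limits leave unreadable from compound 1 to compound 2 cannot be read from two limits (the limit of > 50000 nM in this assay, at which 2 of the 3 values shown sit). The steps of an at least 11-fold lower number from compound 1 to compound 3 (1.06 log units; beyond the scatter) and an at least 11-fold lower number from compound 2 to compound 3 (1.06 log units; beyond the scatter) are both large. Compound 4 `CCC(C)C(NC(=O)c1ccc(C(CC)(CC)c2ccc(OCCC(O)(CC)CC)c(C)c2)n1CC)C(=O)O` differs from compound 1 by 1-carboxy-2-methylbutyl in place of cyanomethyl on an amide-type nitrogen. For the measured compounds named here, only the step to compound 3 bears on this change, both replacing cyanomethyl with a longer chain on the amide-type nitrogen, and that step was an at least 11-fold lower number from compound 1 to compound 3 (1.06 log units; beyond the scatter). A lower number is therefore expected, about an at least 6.2-fold lower number from compound 1 to compound 4 (0.79 log units; beyond the scatter). Compound 4 is estimated at 8000 nM, with a range of 2500 nM to 30000 nM.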

Compound 4, half-maximal inhibitory concentration: 9990 nM
Compound 4: middle estimate off by 1.2-fold (0.10 log units), on the low side; the range from low to high includes it.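

On the amide-type nitrogen, 1-carboxy-2-methylbutyl gives a second readable number in this assay, with an at least 5.0-fold lower number from compound 1 to compound 4 (0.69 log units; beyond the scatter) and an at least 5.0-fold lower number from compound 2 to compound 4 (0.69 log units; beyond the scatter). For the compounds shown here, compound 3 is therefore no longer the only compound to move clear of the limit shared by compound 1 and compound 2. The change within this chain type also matters: a 2.3-fold higher number from compound 3 to compound 4 (0.37 log units; beyond the scatter).

Still open, from the compounds shown here alone, is whether the carboxylic acid of compound 4 or the 2-methylbutyl chain carrying it accounts for the step. An amine on the same chain, or a plain alkyl chain, would separate the two.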